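A few compounds are considered here, and "the series" means these few. Any claim that something is new, unique, unknown or untested is made for them only; others in the source may bear on it.

Compounds with measured values:
Compound 1, `Nc1ncnc2c1c(Oc1cc(C(F)(F)F)ccn1)nn2C1CCCC1`: 0.333 h
Compound 2, `Nc1ncnc2c1c(Oc1cc(C(F)(F)F)ccn1)nn2[C@@H]1CCCC[C@H]1O`: > 2.41 h, a limit of the assay
Compound 3, `Nc1ncnc2c1c(Oc1cc(C(F)(F)F)ccn1)nn2C1CC1`: > 2.41 h, a limit of the assay

For the measured compounds named here, in an ADME assay on microsomes from liver (Homo sapiens) for metabolic stability, read by LC-MS, using NADPH, with a stated time of 10 min, tested at 10 uM (on this read-out lower numbers stand for a shorter-lived compound and higher numbers for a longer-lived compound), compound 1 gives 0.333 h, the only plain number among the three. For compound 2 the assay reports only its limit of > 2.41 h. For compound 3 it likewise reports only the limit of > 2.41 h. Against compound 1 this gives an at least 7.2-fold higher number from compound 1 to compound 2 (0.85 log units; beyond the scatter) and an at least 7.2-fold higher number from compound 1 to compound 3 (0.85 log units; beyond the scatter), both readable as a rise despite the limits, while the comparison shows a step that the two limits leave unreadable from compound 2 to compound 3.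

Compound 4 is `CO[C@H]1CC[C@@H](n2nc(Oc3cc(C(F)(F)F)ccn3)c3c(N)ncnc32)CC1`. It differs from compound 1 in one place: 4-methoxycyclohexyl in place of cyclopentyl on an aromatic nitrogen. Both measured changes of the ring group on that aromatic nitrogen moved the number up to the limit of > 2.41 h in this assay, at which 2 of the 3 values shown sit. Compound 4 changes the same group, so a rise in this assay is expected, with a fair chance that only the limit is reported again. The estimated step is a 6.0-fold higher number from compound 1 to compound 4 (0.78 log units; beyond the scatter). Compound 4 is therefore expected to give about 2 h, within a range from 0.7 h to 4 h.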

Compound 4, half-life: 0.317 h
Compound 4: the middle estimate sits 6.3-fold (0.80 log units) above what was measured, and the stated range ends above it.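

In this assay, putting 4-methoxycyclohexyl in place of cyclopentyl on the aromatic nitrogen gives a 1.1-fold lower number from compound 1 to compound 4 (0.02 log units; within the scatter), so these two compounds cannot be told apart. A new ring group at this position therefore does not always bring the rise seen earlier, and compound 4 goes against that pattern, with an at least 7.6-fold lower number from compound 3 to compound 4 (0.88 log units; beyond the scatter) and an at least 7.6-fold lower number from compound 2 to compound 4 (0.88 log units; beyond the scatter). These two sizes are only minimums, because the values of compound 2 and compound 3 are limits of the assay and not numbers: the limit of > 2.41 h in this assay, at which 2 of the 4 values shown sit.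

The compounds shown leave open whether the gap between 2-hydroxycyclohexyl and 4-methoxycyclohexyl comes from the kind of oxygen group, from where it sits on the ring, or from both, and a plain cyclohexyl or a 4-hydroxycyclohexyl would help separate these possibilities. They also leave open how half-life follows ring size among groups without oxygen, where cyclobutyl would fill the gap between cyclopropyl and cyclopentyl.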